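A methylphenyl swap on a nearly inactive compound

A few compounds are considered here, and "the series" means these few. Any claim that something is new, unique, unknown or untested is made for them only; others in the source may bear on it.

All three measured compounds share one core and differ only in the aromatic group on an amide-type nitrogen: compound 1 `Cc1cccc(NC(=O)C2(C(=O)Nc3ccc(Nc4ncc5cc(C(=O)N(C)C)n(C6CCCC6)c5n4)cc3)CC2)c1`, compound 2 `COC(=O)c1ccc(NC(=O)C2(C(=O)Nc3ccc(Nc4ncc5cc(C(=O)N(C)C)n(C6CCCC6)c5n4)cc3)CC2)cc1` and compound 3 `CN(C)C(=O)c1cc2cnc(Nc3ccc(NC(=O)C4(C(=O)Nc5ccc(Cl)c(C(F)(F)F)c5)CC4)cc3)nc2n1C1CCCC1`. In a functional assay on A549 cells (Homo sapiens) for inhibition, read by CCK-8 assay, with a stated time of 72 h, tested at 1 uM (a higher number here means more inhibition of growth at the concentration tested, a lower number less inhibition of growth), compound 3 gives 1.1%, the lowest of the three, while compound 1 gives 35.2% and compound 2 gives 77.1%.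

Compound 4 `Cc1ccc(NC(=O)C2(C(=O)Nc3ccc(Nc4ncc5cc(C(=O)N(C)C)n(C6CCCC6)c5n4)cc3)CC2)cc1` keeps the core but changes that group: 4-methylphenyl in place of 4-chloro-3-(trifluoromethyl)phenyl on an amide-type nitrogen. In words, 4-methylphenyl stands in place of 4-chloro-3-(trifluoromethyl)phenyl on an amide-type nitrogen.

The nearest guide is the 3-methylphenyl group, whose exchange for the group carried by compound 3 gave a number 34.1 percentage points lower from compound 1 to compound 3 (beyond the scatter). Larger swings occur at the same place, namely a number 41.9 percentage points higher from compound 1 to compound 2 (beyond the scatter) and a number 76 percentage points lower from compound 2 to compound 3 (beyond the scatter), so this position can move this assay a long way. A large upward step is therefore expected, estimated as a number 33.9 percentage points higher from compound 3 to compound 4 (beyond the scatter). For compound 4 the expected value is 35%, with an estimated range from 12% to 65%.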

Compound 4, percent growth inhibition at one concentration: 40.2%
Compound 4: the middle estimate sits 5.2 percentage points below what was measured, within the range that was stated.
By their numbers in this assay, from the lowest: compound 3; then compounds 1 and 4 (each within the scatter of the next); then compound 2.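

In this assay, 4-methylphenyl in place of 4-chloro-3-(trifluoromethyl)phenyl on the amide-type nitrogen gives a number 39.1 percentage points higher from compound 3 to compound 4 (beyond the scatter), so this exchange of one aromatic group for another is enough to bring back growth inhibition. Shifting the methyl group gives a number 5 percentage points higher from compound 1 to compound 4 (within the scatter), so 3-methylphenyl and 4-methylphenyl cannot be told apart here. By contrast, methyl in place of methoxycarbonyl on an aromatic carbon gives a number 36.9 percentage points lower from compound 2 to compound 4 (beyond the scatter), showing that the identity of the group on this ring can matter more than where the methyl group sits.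

Nothing shown here explains why these groups differ. As far as these compounds go, it also remains open whether a carboxylic acid or a primary amide in place of methoxycarbonyl would give a number nearer that of compound 2 or that of compound 4.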